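The source may hold more compounds than are shown below. What is called first, only, known or untested is meant among the compounds shown, and "the series" means these compounds.

Measured so far in a functional assay on RAW264.7 cells (Mus musculus) for inhibition, read by Griess assay, with a stated time of 24 h, in the presence of a further agent that is not named here; a lower number here means a stronger inhibitor, a higher number a weaker inhibitor:
compound 1 `C/C(C=O)=C\C[C@H]1[C@](C)(O)[C@@H](O)C[C@H]2C(C)(C)CCC[C@@]21C` at 93000 nM
compound 2 `CC1=CC(=O)O[C@]12C[C@@H]1[C@@]3(C)CCCC(C)(C)[C@@H]3C[C@H](O)[C@@]1(C)O2` at 49600 nM

Compound 1 stands within the scatter of compound 2, so these two values set no order between them. Compound 3 `C=C/C(C)=C/C[C@H]1[C@](C)(O)[C@@H](O)C[C@H]2C(C)(C)CCC[C@@]21C` has not yet been measured. It keeps the core of compound 1 and carries vinyl in place of formyl on a double-bonded chain carbon bound to a double-bonded chain carbon and a saturated chain carbon. Among the compounds with values here, no measured step covers this change, so the data give it no direction. In this assay no step beyond the scatter is expected, with compound 1 at 93000 nM as the only starting level. The estimated change is a 1.2-fold lower number from compound 1 to compound 3 (0.07 log units; within the scatter) and is expected to stay small. For compound 3 the expected value is 80000 nM with an estimated range from 30000 nM to 200000 nM in this assay.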

Compound 3, half-maximal inhibitory concentration: 49300 nM
Beside the measured number, compound 3's estimate is 1.6-fold (0.21 log units) above it; low and high end bracket the measured number.
By their numbers in this assay, from the lowest: compounds 3, 2 and 1 (each within the scatter of the next).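

In this assay, vinyl in place of formyl on a double-bonded chain carbon bound to a double-bonded chain carbon and a saturated chain carbon gives a 1.9-fold lower number from compound 1 to compound 3 (0.28 log units; within the scatter). Within the data shown here, this is the first comparison that differs in one place, and it shows that at this position the formyl group, with its hydrogen-bond acceptor, can give way to an all-carbon vinyl group without a step beyond the scatter. No supporting data bear on this result.

On these data alone, whether any group at this position can move the number beyond the scatter stays open, and a carboxylic acid, an amine or a longer chain would each test this. As far as these compounds go, compound 2 differs from compound 1 in more than one place, so its link to this position also stays open.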